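Swapping amino for hydroxy at the assay limit

The source may hold more compounds than are shown below. What is called first, only, known or untested is meant among the compounds shown, and "the series" means these compounds.

Measured in a functional assay on CCRF-CEM cells (Homo sapiens) for cytotoxicity; on this read-out lower numbers stand for stronger inhibition and higher numbers for weaker inhibition:
Compound 1 `OC[C@H]1[C@H](n2cnc3c(O)ncnc32)S[C@@H]1CO` gives > 100000 nM as a limit
Compound 2 `Nc1ncnc2c1ncn2[C@H]1S[C@@H](CO)[C@@H]1CO` gives > 100000 nM as a limit

Neither compound has yet given a number in this assay. Compound 2 stands at > 100000 nM, which is a limit of the assay and not a number. The two measured compounds share a single reading, namely (the limit of > 100000 nM in this assay, at which 2 of the 2 values shown sit). Among the compounds with values here, no step between measured compounds is available, so nothing yet sizes a structural change here.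

Compound 3 `OC[C@H]1[C@H](CO)S[C@@H]1n1cnc2c(O)ncnc21` is the next structure to follow from compound 2. The change is hydroxy in place of amino on an aromatic carbon. In words, hydroxy stands in place of amino on an aromatic carbon of a six-membered aromatic ring with 2 nitrogen, part of a fused system of two rings.

The expectation is for no change beyond the scatter, with no direction favoured, because the limit of > 100000 nM in this assay, at which 2 of the 2 values shown sit, is all that the measurements show. The expected size is a number no higher from compound 2 to compound 3 (the limit leaves the size open), which is an estimate only. The assay will most likely report a limit again. For compound 3 the estimated value is 100000 nM, with an expected range from 40000 nM to 250000 nM.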

Compound 3, half-maximal inhibitory concentration: > 100000 nM
Compound 3 was reported as a limit; the forecaster's own chance of this, stated with the estimate: 85%; the middle value lies on the limit itself.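

In this assay compound 3 gives > 100000 nM, which is a limit and not a number. The steps to compound 3 from compound 2 and from compound 1 cannot be read. The compounds shown leave open whether hydroxy in place of amino, or the mirror-image configuration, changes the read-out in this assay at all: the limit of > 100000 nM in this assay, at which 3 of the 3 values shown sit.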